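From tert-butyl to sulfamoyl at the assay limit

The compounds below may be only part of what the source reports. "The series", "measured", "known", "first", "only" and "open" are said of these compounds alone.

Compound 1 `Nc1ccc(C(=O)N/N=C/c2ccc3c(c2)no[n+]3[O-])cc1` gives > 200000 nM as a limit
Compound 2 `O=C(N/N=C/c1ccc2c(c1)no[n+]2[O-])c1ccc(Br)cc1` gives > 200000 nM as a limit
Compound 3 `CC(C)(C)c1ccc(C(=O)N/N=C/c2ccc3c(c2)no[n+]3[O-])cc1` gives > 200000 nM as a limit

In an ADME assay on cells (Fibroblast, Homo sapiens) for inhibition, read by MTT assay, with a stated time of 24 h (a lower number here means a stronger inhibitor, a higher number a weaker inhibitor), compound 3 gives > 200000 nM as a limit and not a number. The three measured compounds together stand at the limit of > 200000 nM in this assay, at which 3 of the 3 values shown sit, and offer no exact value to work from.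

The next compound is compound 4 `NS(=O)(=O)c1ccc(C(=O)N/N=C/c2ccc3c(c2)no[n+]3[O-])cc1` in which sulfamoyl takes the place of tert-butyl on an aromatic carbon, para to a large group (sulfamoyl in place of tert-butyl on an aromatic carbon).

Three measured swaps on an aromatic carbon bear on this change. There is a step that the two limits leave unreadable from compound 1 to compound 2 with bromo in place of amino. There is a step that the two limits leave unreadable from compound 1 to compound 3 with tert-butyl in place of amino. There is a step that the two limits leave unreadable from compound 2 to compound 3 with tert-butyl in place of bromo. None of them has a size that can be read, and none gives a direction.

No step beyond the scatter is therefore expected in this assay for this change. The estimated step is a number no higher from compound 3 to compound 4 (the limit leaves the size open) on this expectation. That expectation rests on compound 3 at > 200000 nM as a limit. For compound 4 the expected value is 200000 nM within an estimated range of 80000 nM to 400000 nM as a cautious guess.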

Compound 4, half-maximal inhibitory concentration: 60000 nM
Estimate against measurement, compound 4: 3.3-fold (0.52 log units) above; the whole stated range lies above it.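

In this assay, among these compounds, sulfamoyl on this aromatic carbon, para to a large group, gives the only step at this position that shows a direction: an at least 3.3-fold lower number from compound 3 to compound 4 (0.52 log units; beyond the scatter) with tert-butyl as the group replaced, an at least 3.3-fold lower number from compound 2 to compound 4 (0.52 log units; beyond the scatter) with bromo, and an at least 3.3-fold lower number from compound 1 to compound 4 (0.52 log units; beyond the scatter) with amino. The swaps among amino, bromo and tert-butyl cannot be read, so only compound 4 shows that a change at this position can bring the read-out within the measurable range. Each of the three steps gives only the least possible size, and the true gaps stay open at the upper end: the limit of > 200000 nM in this assay, at which 3 of the 4 values shown sit.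

The compounds shown leave open how far compound 1, compound 2 and compound 3 lie beyond the limit, and so whether amino, bromo and tert-butyl differ at all from one another. They also leave open whether the lower number belongs to sulfamoyl alone or would also appear with another group at this position, such as a carboxylic acid or a methylsulfonyl group.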